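Chalcone-amide series: aminophenyl replacing dimethoxyphenyl

The source may hold more compounds than are shown below. What is called first, only, known or untested is meant among the compounds shown, and "the series" means these compounds.

Measured so far in a functional assay on PC-3 cells (Homo sapiens) for cytotoxicity, read by MTT assay, with a stated time of 72 h; on this read-out higher numbers stand for weaker inhibition and lower numbers for stronger inhibition:
- compound 1 `COc1ccc(C(=O)c2cc(OC)c(OC)c(OC)c2)cc1NC(=O)/C=C/c1ccc(OC)c(OC)c1`, 7500 nM
- compound 2 `COc1cccc(/C=C/C(=O)Nc2cc(C(=O)c3cc(OC)c(OC)c(OC)c3)ccc2OC)c1`, 4700 nM

Compound 1 gives the highest number of the two; the move to compound 2 is a 1.6-fold lower number from compound 1 to compound 2 (0.20 log units; within the scatter). Compound 3 `COc1ccc(C(=O)c2cc(OC)c(OC)c(OC)c2)cc1NC(=O)/C=C/c1ccc(N)cc1` differs from compound 1 by 4-aminophenyl in place of 3,4-dimethoxyphenyl on a double-bonded chain carbon bound to a double-bonded chain carbon. No measured step covers this change; the only step shown, from compound 1 to compound 2, removes a methoxy elsewhere and stays within scatter. Hence no shift beyond the scatter is expected for compound 3 in this assay, an estimated step of a 1.3-fold lower number from compound 1 to compound 3 (0.10 log units; within the scatter). Compound 3 is expected at 6000 nM, between 2000 nM and 20000 nM.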

Compound 3, half-maximal inhibitory concentration: 15900 nM
The estimate for compound 3 lay 2.7-fold (0.42 log units) below the measured number, within the range that was stated.
By their numbers in this assay, from the lowest: compounds 2 and 1 (each within the scatter of the next); then compound 3.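

At the double-bonded chain carbon bound to a double-bonded chain carbon, 4-aminophenyl in place of 3,4-dimethoxyphenyl gives the first step beyond the scatter in this assay (a 2.1-fold higher number from compound 1 to compound 3 (0.33 log units; beyond the scatter)). 4-Aminophenyl in place of 3-methoxyphenyl points the same way (a 3.4-fold higher number from compound 2 to compound 3 (0.53 log units; beyond the scatter)), so both methoxyphenyl groups shown give stronger inhibition than 4-aminophenyl, though both steps are modest. Nothing available bears on the cause of these shifts.

Still open, going by these compounds, is whether the shift follows the amine itself or where it sits on the ring. A 3-aminophenyl or 4-methoxyphenyl group would help separate the two.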